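Hydroxamate sulfamides: urea amine swap in compound 4

The compounds below may be only part of what the source reports. "The series", "measured", "known", "first", "only" and "open" are said of these compounds alone.

Measured in a functional assay on MONO-MAC-6 cells (Homo sapiens) for inhibition; a higher number here means a weaker inhibitor, a lower number a stronger inhibitor:
compound 1 `C[C@@H](NS(=O)(=O)N1CC=C(c2ccc(Cl)cc2)CC1)C(=O)NO` gives 1240 nM
compound 2 `O=C(NO)[C@H]1CCCCN1S(=O)(=O)N1CC=C(c2ccc(Br)cc2)CC1` gives 1200 nM
compound 3 `CN(C)C(=O)N1CCN(S(=O)(=O)N2CC=C(c3ccc(F)cc3)CC2)[C@@H](C(=O)NO)C1` gives 200 nM

Compound 3 stands lowest of the three numbers in this assay, and its gap to compound 1 and to compound 2 lies beyond the scatter, so among these three it is the strongest inhibitor. The values of compound 1 and compound 2 sit within the scatter of each other.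

Compound 4 `O=C(NO)[C@H]1CN(C(=O)N2CCOCC2)CCN1S(=O)(=O)N1CC=C(c2ccc(F)cc2)CC1` has not yet been measured. It differs from compound 3 only on the urea: morpholin-4-yl in place of dimethylamino on a carbonyl carbon. Among the measured compounds shown here, no measured pair in the set carries this kind of change, so there is no step to lean on; the expectation is a step of no size beyond the scatter, in either direction, a 1.2-fold higher number from compound 3 to compound 4 (0.06 log units; within the scatter). Compound 4 is therefore estimated at 230 nM, with a range from 90 nM to 600 nM.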

Compound 4, half-maximal inhibitory concentration: 350 nM
Beside the measured number, compound 4's estimate is 1.5-fold (0.18 log units) below it; the measured number falls inside the stated range.
By their numbers in this assay, from the lowest: compounds 3 and 4 (each within the scatter of the next); then compounds 2 and 1 (each within the scatter of the next).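

In this assay, morpholin-4-yl in place of dimethylamino on a carbonyl carbon leaves the number within the scatter (a 1.8-fold higher number from compound 3 to compound 4 (0.24 log units; within the scatter)). Among the compounds shown here, the urea position therefore carries a six-membered non-aromatic ring and an added hydrogen-bond acceptor with no step that can be told from the scatter, a reading resting on this single pair. No other measurement bears on this result. Open, from the compounds shown here alone, is whether piperidin-1-yl or 4-methylpiperazin-1-yl on the same carbonyl carbon would also stay within the scatter of compound 3. Going by these compounds, a larger amine such as 4-phenylpiperazin-1-yl also remains open.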